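Methoxy for allyl on the benzyl ring of compound 3

The source may hold more compounds than are shown below. What is called first, only, known or untested is meant among the compounds shown, and "the series" means these compounds.

In an assay on Midbrain with Type-2 angiotensin II receptor (Rattus norvegicus) as the target (on this read-out lower numbers stand for stronger inhibition and higher numbers for weaker inhibition), compound 3 `C=CCc1cc(Cn2c(CC)nc3c(C)cc(C)nc32)ccc1OC(C(=O)O)c1ccccc1` gives 270 nM, the lowest number of the three measured. Compound 2 `CCc1cc(Cn2c(CC)nc3c(C)cc(C)nc32)ccc1OC(C(=O)O)c1ccccc1` gives 410 nM, and the step of a 1.5-fold lower number from compound 2 to compound 3 (0.18 log units; within the scatter) is within the scatter. Compound 1 `CCCc1nc2c(C)ccnc2n1Cc1ccc(OC(C(=O)O)c2ccccc2)cc1` gives 3400 nM, a number far above that of compound 3, but compound 1 also carries a different core, so it offers no single-point comparison. Compound 4 `CCc1nc2c(C)cc(C)nc2n1Cc1ccc(OC(C(=O)O)c2ccccc2)c(OC)c1` differs from compound 3 by methoxy in place of allyl on an aromatic carbon. Among the measured compounds shown here, the only measured step at this aromatic carbon, a 1.5-fold lower number from compound 2 to compound 3 (0.18 log units; within the scatter), exchanged one carbon chain for another and stayed within the scatter; no measured compound carries an oxygen-bound group here. A modest weakening is expected, a 2.2-fold higher number from compound 3 to compound 4 (0.35 log units; beyond the scatter), with wide uncertainty. Compound 4 is estimated at 600 nM, in the range 150 nM to 2500 nM.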

Compound 4, half-maximal inhibitory concentration: 2900 nM
Beside the measured number, compound 4's estimate is 4.8-fold (0.68 log units) below it; the measured number lies above the stated range.
By their numbers in this assay, from the lowest: compounds 3 and 2 (each within the scatter of the next); then compounds 4 and 1 (each within the scatter of the next).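

In this assay, methoxy on the aromatic carbon ortho to a carboxy(phenyl)methoxy group gives an 11-fold higher number from compound 3 to compound 4 (1.03 log units; beyond the scatter) and a 7.1-fold higher number from compound 2 to compound 4 (0.85 log units; beyond the scatter). Both steps lie beyond the scatter, whereas the exchange between the two carbon chains stayed within it, so this position separates the methoxy compound from the allyl and ethyl compounds, something the carbon chains alone could not show. Nothing available bears on the cause of this change.

Going by these compounds, whether methoxy stands for oxygen-bound groups in general stays open: ethoxy or hydroxyl at this carbon would test that. A longer chain such as butyl would show how far the carbon-chain range extends.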